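A few compounds are considered here, and "the series" means these few. Any claim that something is new, unique, unknown or untested is made for them only; others in the source may bear on it.

Four compounds share one core, built around a five-membered aromatic ring with two nitrogens. Compound 1 `Cc1cc(C(=O)O)nn1Cc1cc(Br)ccc1OCc1ccccc1` gives 1.2 in a physicochemical assay for lipophilicity, at pH 7.4; on this read-out lower numbers stand for lower lipophilicity and higher numbers for higher lipophilicity. Compound 2 `Cc1cc(C(=O)O)nn1C(C)c1cc(Cl)ccc1OCc1ccccc1` gives 1 in this assay. Compound 3 `Cc1cc(C(=O)NCc2ccncc2)nn1Cc1cc(Cl)ccc1OCc1ccccc1` returns only a limit in this assay, namely > 3.7, which is not a number. Compound 3 therefore stands at the limit of > 3.7 in this assay, at which 1 of the 3 values shown sits, the top of the three readings. Going by the values given here, no two of the measured compounds differ in only one place, so no single measured step is available to lean on.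

Compound 4 `Cc1cc(NC(=O)OCc2ccccc2)nn1Cc1cc(Cl)ccc1OCc1ccccc1` differs from compound 3 in one place: (benzyloxycarbonyl)amino in place of ((pyridin-4-yl)methyl)carbamoyl on an aromatic carbon.

Compound 3 already sits at the limit > 3.7. The step from compound 3 to compound 4 is expected to be a step that the limit leaves unreadable from compound 3 to compound 4, an upward move that cannot be told apart from none beyond the scatter, with the reading most likely ending at the limit again. For compound 4 the estimate in this assay is 4.3, within a range from 3.7 to 5.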

Compound 4, distribution coefficient: 3.1
Estimate against measurement, compound 4: 1.20 log units above; the whole stated range lies above it.
By their numbers in this assay, from the lowest: compounds 2 and 1 (each within the scatter of the next); then compound 4. At a limit, above all of these: compound 3.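

Going by these compounds alone, this is the first comparison here between two compounds that differ in one place, and it shows that the group on this aromatic carbon can move the reading in this assay. Placing (benzyloxycarbonyl)amino where ((pyridin-4-yl)methyl)carbamoyl stood gives a number at least 0.60 log units lower from compound 3 to compound 4 (beyond the scatter), even though the two groups carry the same counts of hydrogen-bond donors and acceptors. As far as these compounds go, the full size of this step stays unknown because only one end of it is a number: the limit of > 3.7 in this assay, at which 1 of the 4 values shown sits.

Both the link to the core and the ring change in this single exchange, so the compounds shown cannot say which of the two carries the step. Also open, from the compounds shown here alone, is how a plain amine on this aromatic carbon, without the benzyloxycarbonyl part, would read.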